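The compounds below may be only part of what the source reports. "The series", "measured", "known", "first", "only" and "open" are said of these compounds alone.

Working notes on the series. All compounds share one core and differ only at one aromatic carbon. Compound 1 `Cc1ccccc1-n1nc(C)c2c1NC(=O)[C@H](C)S[C@@H]2c1ccc(-c2ccsc2)cc1` carries thiophen-3-yl there; in an assay on isolated protein for agonist activity at Bile acid receptor (Homo sapiens), read by AlphaScreen, with a stated time of 30 min (on this read-out higher numbers stand for larger maximal responses and lower numbers for smaller maximal responses), compound 1 gives 68%. Compound 2 `Cc1ccccc1-n1nc(C)c2c1NC(=O)[C@H](C)S[C@@H]2c1ccc(Oc2ccccc2)cc1` carries phenoxy, and in this assay compound 2 gives 118%. Within the data shown here, on the numbers so far compound 2 stands highest of the two, with compound 1 as its only neighbour, a large distance below. Among the measured compounds shown here, the single measured step is a number 50 percentage points higher from compound 1 to compound 2 (beyond the scatter), so an exchange at this carbon has already moved the maximal response strongly once. Compound 3 `Cc1ccccc1-n1nc(C)c2c1NC(=O)[C@H](C)S[C@@H]2c1ccc(-c2ccccc2)cc1` differs from compound 2 by phenyl in place of phenoxy on an aromatic carbon. For the measured compounds named here, no measured step involves phenyl at this carbon, so the direction rests on the sensitivity alone; a moderate downward move is expected, a number 28 percentage points lower from compound 2 to compound 3 (beyond the scatter). Compound 3 is therefore estimated at 90%, with a range from 55% to 125%.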

Compound 3, largest response reached (reported as efficacy), in percent of the reference or control that the assay uses: 24%
Estimate against measurement, compound 3: 66 percentage points above, outside the stated range (below it).
By their numbers in this assay, from the lowest: compound 3; then compound 1; then compound 2.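

In this assay, the position proves more sensitive than the first pair suggested: phenyl in place of phenoxy gives a number 94 percentage points lower from compound 2 to compound 3 (beyond the scatter), although the two groups differ by only the oxygen atom. Phenyl in place of thiophen-3-yl also lowers the maximal response, with a number 44 percentage points lower from compound 1 to compound 3 (beyond the scatter), so two aromatic rings attached directly at this carbon are not interchangeable, and the lowest of the three numbers belongs to compound 3. Nothing on hand accounts for either drop.

Still open, as far as these compounds go, is whether the high response of compound 2 depends on the oxygen link itself or on the link together with the phenyl ring it carries. A benzyloxy group, a methoxy group or an anilino amine at this carbon would bear on that question.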